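Halogenated phenyl in place of 4-hydroxyphenyl

This account rests on a few compounds, and the source may have more. Where it says the series, first, only, none or still open, it means among the compounds named here.

The three measured compounds share one core and differ only in the aryl group on the carbon with a double bond to nitrogen. In a functional assay on A549 cells (Homo sapiens) for cytotoxicity, read by MTT assay, with a stated time of 72 h (on this read-out higher numbers stand for weaker inhibition and lower numbers for stronger inhibition), compound 1 `CN(C)CCn1cnnc1-c1cc(Oc2ccc(NC(=O)N/N=C/c3ccc(O)c(Br)c3)cc2F)ccn1` gives 1370 nM, compound 2 `CN(C)CCn1cnnc1-c1cc(Oc2ccc(NC(=O)N/N=C/c3ccc(Cl)cc3)cc2F)ccn1` gives 780 nM and compound 3 `CN(C)CCn1cnnc1-c1cc(Oc2ccc(NC(=O)N/N=C/c3ccc(O)cc3)cc2F)ccn1` gives 3560 nM. Compound 3 stands with the highest number of the three: a 4.6-fold higher number from compound 2 to compound 3 (0.66 log units; beyond the scatter) and a 2.6-fold higher number from compound 1 to compound 3 (0.41 log units; beyond the scatter), whereas a 1.8-fold lower number from compound 1 to compound 2 (0.24 log units; within the scatter). Compound 4 `CN(C)CCn1cnnc1-c1cc(Oc2ccc(NC(=O)N/N=C/c3ccc(F)cc3Cl)cc2F)ccn1` carries 2-chloro-4-fluorophenyl in place of 4-hydroxyphenyl on a carbon with a double bond to nitrogen. The two steps that bear on this change both lead away from a halogen, to hydroxy or to hydrogen, and both raised the number; the change to compound 4 runs the other way, from hydroxy to a ring bearing two halogens, so a lower number in this assay is expected, of roughly the size of the larger of those two steps in reverse. The step expected from compound 3 to compound 4 is a 5.1-fold lower number from compound 3 to compound 4 (0.71 log units; beyond the scatter). For compound 4 the estimated value is 700 nM, with a range from 280 nM to 1800 nM.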

Compound 4, half-maximal inhibitory concentration: 1120 nM
Compound 4: the middle estimate sits 1.6-fold (0.20 log units) below what was measured; the range from low to high includes it.
By their numbers in this assay, from the lowest: compounds 2, 4 and 1 (each within the scatter of the next); then compound 3.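

In this assay a second halogenated ring now stands apart from the 4-hydroxyphenyl compound, a 3.2-fold lower number from compound 3 to compound 4 (0.50 log units; beyond the scatter), so this separation at the carbon with a double bond to nitrogen is not confined to the 4-chlorophenyl of compound 2. The 2-chloro-4-fluorophenyl group cannot be told apart from the other two aryl groups, a 1.4-fold higher number from compound 2 to compound 4 (0.16 log units; within the scatter) and a 1.2-fold lower number from compound 1 to compound 4 (0.09 log units; within the scatter), so a ring with two halogens shows no measurable gain over one with a single chloro, and compound 1, which keeps its hydroxy alongside bromo, falls in the same band. No measurement is available to explain these differences.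

Whether the 2-chloro or the 4-fluoro group of compound 4 accounts for the step from compound 3 stays open. Also open, on these data alone, is whether an amino group or a carboxylic acid on this ring would stay with compounds 1, 2 and 4 or move towards compound 3.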